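A few compounds are considered here, and "the series" means these few. Any claim that something is new, unique, unknown or untested is made for them only; others in the source may bear on it.

In a functional assay on ileum (Cavia porcellus) for antagonist activity, with a stated time of 30 s (a higher number here means a weaker inhibitor, a lower number a stronger inhibitor), compound 2 `O=C(O)c1cc(=O)c2ccc(OCCCCCCCOc3ccccc3)cc2o1` gives 1.8 ug/mL. Compound 3 `O=C(O)c1cc(=O)c2ccc(OCCCCCCCCCOc3ccccc3)cc2o1` gives 1.8 ug/mL, so the two stand level. Compound 1 `O=C(O)c1cc(=O)c2c(OCCOc3ccccc3)cccc2o1` gives 100 ug/mL, a far higher number and so a far weaker inhibitor. Compound 4 `COc1cccc(OCCCCCOc2ccc3c(=O)cc(C(=O)O)oc3c2)c1` has not been measured yet. Its difference from compound 2 is 3-methoxyphenoxy in place of 2-phenoxyethyl on a saturated chain carbon, five bonds along the chain from an oxygen on an aromatic ring.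

Among the measured compounds shown here, only one measured step bears on this change: no change at the digits printed from compound 2 to compound 3 (within the scatter), where 2-phenoxyethyl took the place of phenoxy. For the measured compounds named here, no measured compound carries 3-methoxyphenoxy, so this evidence is thin. Little movement is therefore expected in this assay, with some allowance for a higher number because compound 1 reaches 100 ug/mL. The expected change is small, and the estimated step is a 1.7-fold higher number from compound 2 to compound 4 (0.22 log units; within the scatter). For compound 4 the estimated value is 3 ug/mL, with an expected range of 1 ug/mL to 10 ug/mL.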

Compound 4, half-maximal inhibitory concentration: 1.5 ug/mL
Beside the measured number, compound 4's estimate is 2.0-fold (0.30 log units) above it, and the stated range covers the measured number.
By their numbers in this assay, from the lowest: compounds 4, 2 and 3 (each within the scatter of the next); then compound 1.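

In this assay, among the compounds shown here, the step of a 1.2-fold lower number from compound 2 to compound 4 (0.08 log units; within the scatter) is the first look at an end ring that carries a substituent, since compounds 1, 2 and 3 all end in plain phenoxy. At this place on the saturated chain, 3-methoxyphenoxy can stand in for 2-phenoxyethyl without a measurable loss, even though the entering group brings a second hydrogen-bond acceptor at the same count of heavy atoms. Nothing shown gives a reason for this result.

The step swaps the whole group, so the part played by the methoxy cannot be separated from the rest of the change, and a matching compound ending in plain phenoxy would be needed to do that. On these data alone, it also remains open whether an end ring carrying an amine or a carboxylic acid in place of the methoxy would keep the number this low.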